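Chloro to Fluoro Exchange on a Dicyano Aryl Ring

This account rests on a few compounds, and the source may have more. Where it says the series, first, only, none or still open, it means among the compounds named here.

In a functional assay on K562 cells (Homo sapiens) for antiproliferative activity, read by MTT assay (on this read-out lower numbers stand for stronger inhibition and higher numbers for weaker inhibition), compound 1 `Cc1ccc(C(=O)C(=C2NCCN2)c2c(Cl)c(F)c(C#N)c(F)c2C#N)cc1` gives 41.9 ug/mL. Compound 2 `Cc1ccc(C(=O)C(=C2NCCN2)c2c(F)c(F)c(C#N)c(F)c2C#N)cc1` differs from compound 1 in one place, (fluoro in place of chloro on an aromatic carbon), and in this assay compound 2 gives 0.9 ug/mL; the step is a 47-fold lower number from compound 1 to compound 2 (1.67 log units; beyond the scatter).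

Compound 3 `N#Cc1c(F)c(Cl)c(C(C(=O)c2ccc(F)cc2)=C2NCCCN2)c(C#N)c1F` is built on a different core, and how that core differs from the core of compound 1 is not broken down here. In this assay compound 3 gives 1.8 ug/mL.

Compound 4 `N#Cc1c(F)c(F)c(C(C(=O)c2ccc(F)cc2)=C2NCCCN2)c(C#N)c1F` has not yet been measured. Within the data shown here, it differs from compound 3 by fluoro in place of chloro on an aromatic carbon, the same change as the one from compound 1 to compound 2, made at a place described in the same words. If the change acts as it did there, compound 4 should give a lower number than compound 3. Yet compound 3 already starts from a low value, as its result of 1.8 ug/mL shows, and its core is not that of compound 1, so a smaller step is expected, estimated as a 6.0-fold lower number from compound 3 to compound 4 (0.78 log units; beyond the scatter). For compound 4 the expected value in this assay is 0.3 ug/mL, with a likely range from 0.05 ug/mL to 1.5 ug/mL.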

Compound 4, half-maximal inhibitory concentration: 2.5 ug/mL
For compound 4 the middle estimate is 8.3-fold (0.92 log units) below the measured one; the measured number lies above the stated range.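

On the core of compound 3, putting fluoro in place of chloro gives a 1.4-fold higher number from compound 3 to compound 4 (0.14 log units; within the scatter) in this assay, so the exchange makes no readable difference in this pair. Set beside the earlier pair, the same exchange at a place described in the same words did not carry over from one core to the other, and its result here cannot be predicted from the earlier step: the same change on two cores in this assay, a 47-fold lower number (1.67 log units; beyond the scatter) from compound 1 to compound 2 and a 1.4-fold higher number (0.14 log units; within the scatter) from compound 3 to compound 4, 65-fold (1.81 log units) apart, beyond the scatter of two such steps. This shows that, for these two pairs, the size of the step depends on the core it is made on, but it does not show which feature of the cores is responsible, and two pairs give no general rule for the series.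

The compounds shown leave open how other groups at this place, such as bromo, methyl or an amine, would read on either core. They also leave open what the same exchange would do on a third core, for example one that keeps the ring of compound 1 but carries the other aryl ketone of compound 3.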